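Butyl to cyclobutyl on the aminopyrimidine-bearing core

The source may hold more compounds than are shown below. What is called first, only, known or untested is meant among the compounds shown, and "the series" means these compounds.

Two compounds share a core, compound 1 `CCc1cnc(-c2nn(Cc3ccccc3F)c3ncccc23)nc1N` and compound 2 `CCCCc1cnc(-c2nn(Cc3ccccc3F)c3ncccc23)nc1N`. In a functional assay (aorta) with Oryctolagus cuniculus as the target (a higher number here means a weaker inhibitor, a lower number a stronger inhibitor), compound 1 gives 272000 nM, and compound 2 gives 218000 nM, a step of a 1.2-fold lower number from compound 1 to compound 2 (0.10 log units; within the scatter). Compound 3 `Nc1nc(-c2nn(Cc3ccccc3F)c3ncccc23)ncc1C1CCC1` is not yet measured; it differs from compound 2 by cyclobutyl in place of butyl on an aromatic carbon. Among the measured compounds shown here, only the step from compound 1 to compound 2 touches this position, and it stayed within the scatter, so compound 3 is expected to show a step of a 1.1-fold lower number from compound 2 to compound 3 (0.04 log units; within the scatter), not beyond the scatter. Compound 3 is estimated at 200000 nM, between 100000 nM and 400000 nM.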

Compound 3, half-maximal inhibitory concentration: 633000 nM
Beside the measured number, compound 3's estimate is 3.2-fold (0.50 log units) below it; the measured number lies above the stated range.
By their numbers in this assay, from the lowest: compounds 2 and 1 (each within the scatter of the next); then compound 3.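

In this assay, the position had seemed indifferent to chain length, but replacing the chain with a ring changes the number: cyclobutyl in place of butyl gives a 2.9-fold higher number from compound 2 to compound 3 (0.46 log units; beyond the scatter), and cyclobutyl in place of ethyl gives a 2.3-fold higher number from compound 1 to compound 3 (0.37 log units; beyond the scatter). Both steps are modest but beyond the scatter. This aromatic carbon, ortho to the amino group, therefore does respond to its group, since butyl and cyclobutyl have the same carbon count and the ring gives the weaker inhibitor. From the compounds shown here alone, whether cyclopropyl or a branched chain such as isopropyl would also give a higher number stays open. Nothing shown here explains the shift.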